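The compounds below may be only part of what the source reports. "The series", "measured", "known", "first", "only" and "open" are said of these compounds alone.

The compounds here were compared in a functional assay, read by spectrophotometry, with a stated time of 3 min; a higher number here means a weaker inhibitor, a lower number a stronger inhibitor. Compound 1, `Cc1ccc2[nH]c(=O)c(/C=N/c3ccc(O)cc3)cc2c1`, gives 5240 nM in this assay. Compound 2, `O=c1[nH]c2ccccc2cc1/C=N/c1ccc(O)cc1`, gives 7150 nM in this assay. Compound 3, `Cc1ccc2[nH]c(=O)c(/C=N/Cc3ccccc3)cc2c1`, gives 607000 nM in this assay.

Two changes connect the measured compounds. The first is hydrogen in place of methyl on an aromatic carbon, and in this assay it made a 1.4-fold higher number from compound 1 to compound 2 (0.13 log units; within the scatter). The second is the change that separates the two cores, (benzyl in place of 4-hydroxyphenyl on a double-bonded nitrogen), and in this assay it made a 120-fold higher number from compound 1 to compound 3 (2.06 log units; beyond the scatter). So the swap at the double-bonded nitrogen moves the number a long way, while the swap of methyl for hydrogen on the ring leaves it essentially where it was.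

Compound 4, `O=c1[nH]c2ccccc2cc1/C=N/Cc1ccccc1`, has not yet been measured. It differs from compound 3 by hydrogen in place of methyl on an aromatic carbon. Among the measured compounds shown here, this is the same change as the one from compound 1 to compound 2, at a place described in the same words, so the earlier step is the natural guide. On the core of compound 3 the change is therefore expected to make a 1.3-fold higher number from compound 3 to compound 4 (0.12 log units; within the scatter), beside the earlier step of a 1.4-fold higher number from compound 1 to compound 2 (0.13 log units; within the scatter), resting on compound 3 at 607000 nM as the starting point. Compound 4 is thus estimated at 800000 nM in this assay, with a likely range from 300000 nM to 2500000 nM, and with weak inhibition of this size the assay may report only a limit.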

Compound 4, half-maximal inhibitory concentration: 368000 nM
For compound 4 the middle estimate is 2.2-fold (0.34 log units) above the measured one, and the stated range covers the measured number.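

In this assay, hydrogen in place of methyl on an aromatic carbon made a 1.6-fold lower number from compound 3 to compound 4 (0.22 log units; within the scatter). Set beside the same change on the other core, this step does not differ from the earlier one by more than repeated measurements would be expected to: the same change on two cores in this assay, a 1.4-fold higher number (0.13 log units; within the scatter) from compound 1 to compound 2 and a 1.6-fold lower number (0.22 log units; within the scatter) from compound 3 to compound 4, 2.3-fold (0.35 log units) apart, within the scatter of two such steps. So the two pairs agree that this swap leaves the number essentially where it was, and the opposite directions of the two steps should not be read as a real difference between the cores, but two pairs cannot show that the change would behave the same way on any other core in the series, or that a real effect smaller than the scatter is absent.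

The compounds shown carry only methyl or hydrogen on this ring carbon, so it remains open whether a chlorine atom, a methoxy group or a longer chain there would move the number any further. As far as these compounds go, it also remains open how the number would respond on the other side of the double-bonded nitrogen to anything other than 4-hydroxyphenyl and benzyl, such as a phenyl ring bearing an amine or a carboxylic acid.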